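This account rests on a few compounds, and the source may have more. Where it says the series, first, only, none or still open, it means among the compounds named here.

Series notes. Compound 1 `CN(C)C(=O)c1cc2cnc(Nc3ccc(NC(=O)C4(C(=O)Nc5ccccc5)CC4)cc3)nc2n1C1CCCC1` gives 77.1% in a functional assay on OVCAR-5 cells (Homo sapiens) for inhibition, read by CCK-8 assay, with a stated time of 72 h, tested at 10 uM; on this read-out higher numbers stand for more inhibition of growth at the one concentration tested and lower numbers for less inhibition of growth. Compound 2 `CN(C)C(=O)c1cc2cnc(Nc3ccc(NC(=O)C4(C(=O)Nc5cccc(O)c5)CC4)cc3)nc2n1C1CCCC1` gives 86%, and compound 3 `CN(C)C(=O)c1cc2cnc(Nc3ccc(NC(=O)C4(C(=O)Nc5cccc(Cl)c5)CC4)cc3)nc2n1C1CCCC1` gives 88.1%, the highest of the three numbers shown: the step of a number 2.1 percentage points higher from compound 2 to compound 3 (within the scatter) lies within the scatter, whereas the step of a number 11 percentage points higher from compound 1 to compound 3 (beyond the scatter) is beyond it, and the step of a number 8.9 percentage points higher from compound 1 to compound 2 (within the scatter) is within it. Compound 4 `CN(C)C(=O)c1cc2cnc(Nc3ccc(NC(=O)C4(C(=O)Nc5cccc(Br)c5)CC4)cc3)nc2n1C1CCCC1` carries bromo in place of chloro on an aromatic carbon. Within the data shown here, no measured step exchanges one halogen for another; the steps that touch this aromatic carbon are a number 11 percentage points higher from compound 1 to compound 3 (beyond the scatter), modest, and a number 2.1 percentage points higher from compound 2 to compound 3 (within the scatter), within the scatter. No step beyond the scatter is therefore expected, a number 2.1 percentage points lower from compound 3 to compound 4 (within the scatter). Compound 4 is expected to give 86%, within the range 77% to 94%.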

Compound 4, percent growth inhibition at one concentration: 89.6%
For compound 4 the middle estimate is 3.6 percentage points below the measured one; low and high end bracket the measured number.
By their numbers in this assay, from the lowest: compounds 1, 2, 3 and 4 (each within the scatter of the next, the first and the last beyond it).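

Working from this assay, this is the first direct exchange of one halogen for another at this position, and it cannot separate bromo from chloro: a number 1.5 percentage points higher from compound 3 to compound 4 (within the scatter). Bromo also cannot be separated from hydroxy, a number 3.6 percentage points higher from compound 2 to compound 4 (within the scatter), whereas a number 12.5 percentage points higher from compound 1 to compound 4 (beyond the scatter) gives a second halogen step from hydrogen that lies beyond the scatter. No evidence on why these steps arise is available here.

From the compounds shown here alone, whether fluoro, an amine or a carboxylic acid on this aromatic carbon would stay with the halogens remains open. A single tested concentration also leaves open whether compound 2, compound 3 and compound 4 differ at lower concentrations.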